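Chloroacetamide replacing methacrylamide on the shared benzothiazole-free core

The source may hold more compounds than are shown below. What is called first, only, known or untested is meant among the compounds shown, and "the series" means these compounds.

Notes on the series. Compound 1 `C/C=C/C(=O)Nc1cccc(-c2nc3ccccc3s2)c1` has been measured in an ADME assay on HEK293 cells (Homo sapiens) for inhibition, with a stated time of 72 h; on this read-out lower numbers stand for an effect already at smaller amounts and higher numbers for an effect only at larger amounts of compound; in this assay compound 1 gives only a limit, > 25000 nM. Compound 2 `C=C(C)C(=O)Nc1cccc(-c2nc3ccccc3s2)c1` also reaches only a limit in this assay, > 25000 nM. The step that the two limits leave unreadable from compound 1 to compound 2 is therefore not readable, and the limit of > 25000 nM in this assay, at which 2 of the 2 values shown sit, is all the evidence there is. Compound 3 `O=C(CCl)Nc1cccc(-c2nc3ccccc3s2)c1` differs from compound 2 by chloromethyl in place of 1-methylethenyl on a carbonyl carbon. Going by the values given here, no measured step bears on this change, so no direction can be drawn; the step of an at least 1.2-fold lower number from compound 2 to compound 3 (0.09 log units; that floor lies within the scatter) is expected to stay within the scatter, and compound 3 is estimated at 20000 nM with a range of 5000 nM to 60000 nM.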

Compound 3, half-maximal effective concentration: 10000 nM
Beside the measured number, compound 3's estimate is 2.0-fold (0.30 log units) above it; the range from low to high includes it.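

In this assay, going by these compounds alone, chloromethyl on the carbonyl carbon gives the first readable steps: an at least 2.5-fold lower number from compound 2 to compound 3 (0.39 log units; beyond the scatter), and an at least 2.5-fold lower number from compound 1 to compound 3 (0.39 log units; beyond the scatter). Both sizes are only floors, since the two earlier compounds sit at a limit of the assay: the limit of > 25000 nM in this assay, at which 2 of the 3 values shown sit. The group on this carbonyl carbon can therefore move the read-out, which prop-1-en-1-yl and 1-methylethenyl alone could not show, and the step between those two cannot be read.

On these data alone, whether the chlorine or the loss of the double bond matters stays open. Bromomethyl or plain methyl at this place would bear on that.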